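Swapping a Methoxy for Hydrogen on a Benzyl Group

The source may report more compounds than this note shows. Statements on the series, on what has been measured and on what is new or still open speak of the compounds shown alone.

In a functional assay on K562 cells (Homo sapiens) for inhibition, read by fluorescence, with a stated time of 72 h (on this read-out lower numbers stand for stronger inhibition of growth and higher numbers for weaker inhibition of growth), compound 1 `CC(C)CCn1cnc2c(Nc3ccc(Cl)cc3)nc(N[C@H]3CC[C@H](N)CC3)nc21` gives 1800 nM and compound 2 `COc1ccc(Cn2cnc3c(Nc4cccc(Cl)c4)nc(N[C@H]4CC[C@H](N)CC4)nc32)cc1` gives 2800 nM as its number, so the two lie within the usual scatter of each other. Compound 3 `N[C@H]1CC[C@H](Nc2nc(Nc3cccc(Cl)c3)c3ncn(Cc4ccccc4)c3n2)CC1` differs from compound 2 in one place, with hydrogen in place of methoxy on an aromatic carbon so that 4-methoxybenzyl becomes benzyl. Within the data shown here, no measured pair here shows this change, so no step beyond the scatter is expected. The estimated step of a 1.1-fold lower number from compound 2 to compound 3 (0.05 log units; within the scatter) is correspondingly small. For compound 3 the expected number is 2500 nM with an estimated range from 900 nM to 7000 nM in this assay.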

Compound 3, concentration for 50% growth inhibition: 3000 nM
Beside the measured number, compound 3's estimate is 1.2-fold (0.08 log units) below it, and the stated range covers the measured number.
By their numbers in this assay, from the lowest: compounds 1, 2 and 3 (each within the scatter of the next).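

Taking the methoxy off the 4-methoxybenzyl group to leave benzyl gives a 1.1-fold higher number from compound 2 to compound 3 (0.03 log units; within the scatter) in this assay. Among these compounds, this pair is the first direct reading of this change, and at this position on the aromatic ring methoxy and hydrogen cannot be told apart by this measure. No supporting data bear on why the two compounds match.

The compounds shown leave open whether an amine or a carboxylic acid on the same aromatic carbon would give a step beyond the scatter. One pair also cannot show whether this swap would read the same on other compounds.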